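A few compounds are considered here, and "the series" means these few. Any claim that something is new, unique, unknown or untested is made for them only; others in the source may bear on it.

Compound 1 `COCCOc1nn(C)c2ncnc(NS(=O)(=O)c3cccc(Cl)c3Cl)c12`: >= 463000 nM (limit)
Compound 2 `COc1nn(C)c2nc(N)nc(NS(=O)(=O)c3cccc(Cl)c3Cl)c12`: >= 649000 nM (limit)

In a physicochemical assay for solubility, read by chemiluminescence, measured as kinetic solubility (on this read-out higher numbers stand for higher solubility and lower numbers for lower solubility), compound 2 stands at >= 649000 nM, which is a limit and not a number. Compound 1 gives >= 463000 nM, which is also a limit. Among the measured compounds shown here, no step between measured compounds is available.

Compound 3 `COc1nn(C)c2nc(NC(C)C)nc(NS(=O)(=O)c3cccc(Cl)c3Cl)c12` carries isopropyl in place of hydrogen on a nitrogen on an aromatic ring, amino to isopropylamino (isopropyl in place of hydrogen on a nitrogen on an aromatic ring).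

A downward step somewhat beyond the scatter is expected in this assay, estimated from the limit as an at least 2.5-fold lower number from compound 2 to compound 3 (0.41 log units; beyond the scatter). For compound 3 the estimated value is 250000 nM, with an expected range of 70000 nM to 650000 nM.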

Compound 3, solubility: >= 551000 nM
Compound 3 ended at the assay's limit (the forecaster's own chance of this, stated with the estimate: 40%); middle value at least 2.2-fold (0.34 log units) away from the limit.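

In this assay, among the compounds shown here, compound 2 and compound 3 both stand at limits, and no step between them can be read. The compounds shown leave open whether isopropyl in place of hydrogen shifts the read-out at all.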